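Adding a Trifluoromethoxy Group to Compound 1

A few compounds are considered here, and "the series" means these few. Any claim that something is new, unique, unknown or untested is made for them only; others in the source may bear on it.

Compound 1 `Fc1ccccc1Nc1nc2nonc2nc1Nc1ccccc1` is the starting point: in an assay on mitochondria from L6 cells (Rattus norvegicus) for activation, with a stated time of 90 min (on this read-out higher numbers stand for an effect only at larger amounts of compound and lower numbers for an effect already at smaller amounts), compound 1 gives 2200 nM, the lowest number among the three measured compounds. Compound 2 `Fc1ccccc1Nc1nc2nonc2nc1NC1CCCCC1` gives 13400 nM, and compound 3 `CCOc1ccccc1Nc1nc2nonc2nc1Nc1ccccc1F` gives 5600 nM. Compound 4 `Fc1ccccc1Nc1nc2nonc2nc1Nc1cccc(OC(F)(F)F)c1` differs from compound 1 by trifluoromethoxy in place of hydrogen on an aromatic carbon. Among the measured compounds shown here, no measured step makes this same change. The closest comparisons both point the same way: a 2.5-fold higher number from compound 1 to compound 3 (0.41 log units; beyond the scatter), and a 6.1-fold higher number from compound 1 to compound 2 (0.78 log units; beyond the scatter), so every change made to compound 1 so far has raised its number. A similar, modest rise is therefore expected here, roughly a 1.6-fold higher number from compound 1 to compound 4 (0.20 log units; within the scatter). Compound 4 is estimated at 3500 nM, with a likely range from 1200 nM to 10000 nM.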

Compound 4, half-maximal effective concentration: 600 nM
For compound 4 the middle estimate is 5.8-fold (0.77 log units) above the measured one, and the stated range ends above it.
By their numbers in this assay, from the lowest: compound 4; then compound 1; then compound 3; then compound 2.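

In this assay, among the compounds shown here, trifluoromethoxy in place of hydrogen on an aromatic carbon gives a 3.7-fold lower number from compound 1 to compound 4 (0.56 log units; beyond the scatter) and is the first change to compound 1 here that lowers the number. An added group, meta to a large group, can therefore improve on compound 1 rather than cost it, so a larger substituent on this ring is not in itself a penalty. Nothing available explains why the number fell. The compounds shown leave open whether this drop belongs to trifluoromethoxy itself, or would also come with methoxy, chlorine or an amine on the same carbon.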